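Swapping chloro for hydrogen on compound 1

The compounds below may be only part of what the source reports. "The series", "measured", "known", "first", "only" and "open" are said of these compounds alone.

One early question about a new compound is how well it holds up in an ADME assay on microsomes from liver (Mus musculus) for metabolic stability, read by LC-MS, using NADPH, with a stated time of 10 min, tested at 0.5 uM; on this read-out lower numbers stand for a less stable compound and higher numbers for a more stable compound. Here compound 1 (`COC(=O)Nc1cc(-c2cnc(OC[C@@](C)(N)CC(C)C)c(Cl)c2)ccn1`) gives 65%. Two relatives were tested in the same way: compound 2 (`COC(=O)Nc1cc(-c2ccc(OC[C@@](C)(N)CC(C)C)c(F)c2)ccn1`) gives 71%, and compound 3 (`CC(=O)Nc1cc(-c2ccc(OC[C@@H](N)CC(C)C)c(C)c2)ccn1`) gives 64%. All three numbers lie within the usual scatter of one another, so compound 1 cannot be told apart from either relative.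

Compound 4 (`COC(=O)Nc1cc(-c2ccc(OC[C@@](C)(N)CC(C)C)nc2)ccn1`) has not yet been measured. It is compound 1 with hydrogen in place of chloro on an aromatic carbon. That carbon belongs to a six-membered aromatic ring with 1 nitrogen and is ortho to a (2-amino-2,4-dimethylpentyl)oxy group.

For the measured compounds named here, no two measured compounds differ in just one place, so this swap has no direct precedent in the data. Compound 2 and compound 3 each differ from compound 1 in more than one place, yet compound 2 at 71% and compound 3 at 64% remain within the scatter of it. On that basis, no step beyond the scatter is expected in this assay, in either direction. The expected change is a number 2 percentage points higher from compound 1 to compound 4 (within the scatter). Compound 4 is estimated at 67%, with an expected range from 50% to 82%.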

Compound 4, percent of the compound remaining: 79%
Estimate against measurement, compound 4: 12 percentage points below; the measured number falls inside the stated range.
By their numbers in this assay, from the lowest: compounds 3, 1, 2 and 4 (each within the scatter of the next, the first and the last beyond it).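

In this assay, replacing chloro with hydrogen gives a number 14 percentage points higher from compound 1 to compound 4 (beyond the scatter), the only change in a single place among these compounds and one that lies beyond the usual scatter. It shows that this aromatic carbon, ortho to the (2-amino-2,4-dimethylpentyl)oxy group and two atoms from the ring nitrogen, is a place where one small substitution can move the read-out by a modest but measurable amount, and that the chloro is not needed to keep the number high in this pair. Nothing available explains why the number rises with this swap.

The compounds shown leave open whether any substituent at this carbon would lower the number relative to hydrogen or whether the effect is specific to chloro, a question that a methoxy group or a nitrile in the same place could help answer. For the compounds shown here, with only this one pair, it also remains open whether the same swap would give a similar step on a compound that differs elsewhere, such as one with another group on the amine-bearing chain.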